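The compounds below may be only part of what the source reports. "The series", "measured", "known", "first", "only" and "open" are said of these compounds alone.

In a functional assay on K562 cells (Homo sapiens) for cytotoxicity, read by MTT assay, with a stated time of 48 h (a lower number here means a stronger inhibitor, a higher number a weaker inhibitor), compound 1 `COc1ccc(-c2cn(C(=O)Nc3cc(OC)c(OC)c(OC)c3)c(=O)n2-c2cc(OC)c(OC)c(OC)c2)cc1` gives 3800 nM. Going by these compounds, compound 2 `COc1ccc(-c2cn(C(=O)Nc3cc(OC)c(OC)c(OC)c3)c(=O)n2-c2cc(OC)c(OC)c(OC)c2)cc1OC` reads > 50000 nM, which is a limit of the assay and not a number, so its true position is unknown.

Compound 3 `COc1ccc(-c2cn(C(=O)Nc3cc(OC)c(OC)c(OC)c3)c(=O)n2-c2cc(OC)c(OC)c(OC)c2)cc1N` differs from compound 2 at one place: amino in place of methoxy on an aromatic carbon. This is amino in place of methoxy on an aromatic carbon, ortho to a methoxy group and meta to a large group, so 3,4-dimethoxyphenyl becomes 3-amino-4-methoxyphenyl.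

Among the measured compounds shown here, only one measured step bears on this carbon: methoxy in place of hydrogen gave an at least 13-fold higher number from compound 1 to compound 2 (1.11 log units; beyond the scatter). With that methoxy gone from compound 3, part of this loss is expected to reverse, although amino is not hydrogen. The expected change in this assay is therefore large and downward, estimated as an at least 8.3-fold lower number from compound 2 to compound 3 (0.92 log units; beyond the scatter). The estimate for compound 3 is 6000 nM, with an expected range of 800 nM to 40000 nM.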

Compound 3, half-maximal inhibitory concentration: 5800 nM
The estimate for compound 3 lay 1.0-fold (0.01 log units) above the measured number; low and high end bracket the measured number.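

In this assay, amino at this carbon brings back the activity that methoxy removes, with a change of an at least 8.6-fold lower number from compound 2 to compound 3 (0.93 log units; beyond the scatter). Going by these compounds, that step has only a lower bound, and its true size is unknown, as compound 2 rests on a limit and not a number: the limit of > 50000 nM in this assay, at which 1 of the 3 values shown sits. Amino in place of hydrogen gives a 1.5-fold higher number from compound 1 to compound 3 (0.18 log units; within the scatter), so compound 1 and compound 3 cannot be told apart, and among these three compounds only the methoxy form stands out.

On these data alone, whether the recovery belongs to amino itself or only to the absence of methoxy stays open, and a hydroxyl, a methyl or an acetamide at this carbon would separate the two. The three compounds say nothing about other positions of the shared core.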